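Ring methyl on compound 2: working notes

The source may report more compounds than this note shows. Statements on the series, on what has been measured and on what is new or still open speak of the compounds shown alone.

In a functional assay on the whole organism for antagonist activity, with Mus musculus as the target (on this read-out higher numbers stand for an effect only at larger amounts of compound and lower numbers for an effect already at smaller amounts), compound 1 `O=C1CCCN1CC#CCn1cnc2ccccc21` gives 80 mg/kg, but its structure differs from the others in more than one place, so it does not inform the step considered here. Compound 2 `CC(=O)N(C)C(C)C#CCn1ccnc1` gives > 100 mg/kg, which is a limit of the assay and not a number. Among the measured compounds shown here, it is the only compound of the three measured that stands at the limit of > 100 mg/kg in this assay, at which 1 of the 3 values shown sits.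

Compound 4 `CC(=O)N(C)C(C)C#CCn1ccnc1C` is compound 2 with one change, methyl in place of hydrogen on an aromatic carbon, between two ring nitrogen atoms and next to the ring atom that bears a large group.

Compound 3 `CC(=O)N(C)C(C)C#CCn1cncc1C` gives 1.1 mg/kg and carries its methyl on a different aromatic carbon of the same ring. For the measured compounds named here, the only measured step of this kind is an at least 90-fold lower number from compound 2 to compound 3 (1.95 log units; beyond the scatter), which is large and beyond the scatter. That single step, at another ring carbon, supports the same direction in this assay but not the same size, and a limit value may recur. The expected change is an at least 12-fold lower number from compound 2 to compound 4 (1.09 log units; beyond the scatter), a smaller shift than the measured one. For compound 4 the estimate is 8 mg/kg, with an expected range of 1 mg/kg to 70 mg/kg.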

Compound 4, dose for half-maximal effect: 0.05 mg/kg
Estimate against measurement, compound 4: 160-fold (2.20 log units) above; the measured number lies below the stated range.
By their numbers in this assay, from the lowest: compound 4; then compound 3; then compound 1. At a limit, above all of these: compound 2.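

In this assay, methyl in place of hydrogen on the aromatic carbon between two ring nitrogen atoms gives an at least 2000-fold lower number from compound 2 to compound 4 (3.30 log units; beyond the scatter), so a single added carbon at this position is enough to turn a compound without a measured number into the lowest number in the series. The value of compound 2, > 100 mg/kg, is a limit of the assay and not a number. The earlier compounds shown here showed a methyl effect at one ring carbon only; now compound 3 gives 1.1 mg/kg and compound 4 gives 0.05 mg/kg, so the printed values show that the place of the methyl on the ring matters in this assay, with the lower number at the carbon that lies between two ring nitrogen atoms.

Still open, on these data alone, is whether a longer chain such as ethyl, a chlorine atom or an amine at this position would keep a number this low, or whether the methyl itself is the requirement. Also open, as far as these compounds go, is whether methyl at this position would shift the number on the core of compound 1, which gives 80 mg/kg.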